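Replacing trifluoroethyl with a fluorophenyl ring on the shared core

The source may report more compounds than this note shows. Statements on the series, on what has been measured and on what is new or still open speak of the compounds shown alone.

Going by the values given here, only two compounds have been measured in an assay on CHO cells for activation of soluble guanylate cyclase alpha1/beta1 complex (Homo sapiens), read by cGMP accumulation; on this read-out lower numbers stand for an effect already at smaller amounts and higher numbers for an effect only at larger amounts of compound. Compound 1 `CC1(C)C(=O)Nc2nc(-n3nc(Cc4c(F)ccc(F)c4F)c4ccccc43)nc(N)c21` gives 2000 nM. Compound 2 `CC1(C)C(=O)Nc2nc(-n3nc(CCC(F)(F)F)c4ccccc43)nc(N)c21` gives 882000 nM, the highest of the two numbers; its nearest neighbour is compound 1, separated by a 440-fold higher number from compound 1 to compound 2 (2.64 log units; beyond the scatter). That single step, 2,2,2-trifluoroethyl in place of 2,3,6-trifluorophenyl on a saturated chain carbon bound to an aromatic carbon, is the only one available, and it was large.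

Compound 3 `CC1(C)C(=O)Nc2nc(-n3nc(Cc4ccccc4F)c4ccccc43)nc(N)c21` has not yet been measured. It differs from compound 2 by 2-fluorophenyl in place of 2,2,2-trifluoroethyl on a saturated chain carbon bound to an aromatic carbon. This largely reverses the measured step, returning an aromatic ring to the place where the open-chain group of compound 2 sits. The step of a 440-fold higher number from compound 1 to compound 2 (2.64 log units; beyond the scatter) bears directly on this change: it removed an aromatic ring from the same place and was large. A large step in the opposite direction is therefore expected for compound 3, though the ring entering is 2-fluorophenyl rather than the 2,3,6-trifluorophenyl of compound 1, so the number need not fall all the way back. Compound 3 is expected at 6000 nM, with a range from 1000 nM to 40000 nM. This estimate means a 150-fold lower number from compound 2 to compound 3 (2.17 log units; beyond the scatter).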

Compound 3, half-maximal effective concentration: 3000 nM
Beside the measured number, compound 3's estimate is 2.0-fold (0.30 log units) above it; low and high end bracket the measured number.
By their numbers in this assay, from the lowest: compounds 1 and 3 (each within the scatter of the next); then compound 2.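

In this assay, placing 2-fluorophenyl on the saturated chain carbon bound to an aromatic carbon gives a 290-fold lower number from compound 2 to compound 3 (2.47 log units; beyond the scatter) and so shows that the large gap seen earlier can be closed by a ring other than the 2,3,6-trifluorophenyl of compound 1. Comparing the two fluorinated rings gives a 1.5-fold higher number from compound 1 to compound 3 (0.18 log units; within the scatter) and so shows no readable difference between 2-fluorophenyl and 2,3,6-trifluorophenyl at this place, which means that the fluorine pattern on the ring, as far as these two compounds go, does not separate them on this read-out. Nothing at hand gives a reason why both rings stand so far from the 2,2,2-trifluoroethyl group of compound 2.

The compounds shown leave open whether fluorine on the ring is needed at all, which a plain phenyl group would test, and whether the ring must be carbon only, which a pyridine ring would test. They also leave open whether a saturated ring such as cyclohexyl, or an open chain without fluorine such as a propyl group, would stand with the aromatic rings or with compound 2.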